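A few compounds are considered here, and "the series" means these few. Any claim that something is new, unique, unknown or untested is made for them only; others in the source may bear on it.

In a functional assay on DU-145 cells (Homo sapiens) for inhibition, read by trypan blue exclusion, with a stated time of 96 h (on this read-out higher numbers stand for weaker inhibition of growth and lower numbers for stronger inhibition of growth), compound 1 `Cc1cc(C)cc(/C=C(\C(=O)c2ccc(Cl)cc2)S(=O)(=O)c2ccc(Br)cc2)c1` gives 10000 nM, the second highest of the three numbers recorded. Compound 2 `O=C(/C(=C\c1ccccc1F)S(=O)(=O)c1ccc(Br)cc1)c1ccc(Cl)cc1` gives 25000 nM, a step of a 2.5-fold higher number from compound 1 to compound 2 (0.40 log units; beyond the scatter). Compound 3 `CSc1ccc(/C=C(\C(=O)c2ccc(Br)cc2)S(=O)(=O)c2ccc(C)cc2)cc1` gives 1000 nM, but it differs from compound 1 in more than one place, so only its value can be set beside that of compound 1.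

Compound 4 `Cc1cc(C)cc(/C=C(\C(=O)c2ccc(Cl)cc2)S(=O)(=O)Cc2ccc(Cl)cc2)c1` differs from compound 1 at a different site: 4-chlorobenzyl in place of 4-bromophenyl on a sulfonyl sulfur. For the measured compounds named here, no measured step touches the group on the sulfonyl sulfur; the only measured step, from compound 1 to compound 2, concerns the other arm of the core. With nothing to lean on, the expected step of no change at the digits printed from compound 1 to compound 4 (within the scatter) is none beyond the scatter. Compound 4 is therefore estimated at 10000 nM, within 3000 nM to 30000 nM.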

Compound 4, concentration for 50% growth inhibition: 1000 nM
The estimate for compound 4 lay 10-fold (1.00 log units) above the measured number; the whole stated range lies above it.
By their numbers in this assay, from the lowest: compounds 3 and 4 (each within the scatter of the next); then compound 1; then compound 2.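

In this assay, the group on the sulfonyl sulfur proves able to shift the number: 4-chlorobenzyl in place of 4-bromophenyl gives a 10-fold lower number from compound 1 to compound 4 (1.00 log units; beyond the scatter), whereas the earlier step on the other arm, a 2.5-fold higher number from compound 1 to compound 2 (0.40 log units; beyond the scatter), went the other way. The change swaps bromine for chlorine and adds a carbon at once, so the step cannot be assigned to either alone. No measurement shown accounts for this step.

As far as these compounds go, it remains open whether 4-bromobenzyl on the sulfonyl sulfur would keep the lower number, which would separate the halogen from the added carbon. From the compounds shown here alone, how a 2-phenylethyl chain or an amine would fare at this place is also open.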